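Replacing a phenyl with a chloro on compound 1

This account rests on a few compounds, and the source may have more. Where it says the series, first, only, none or still open, it means among the compounds named here.

In a functional assay on HL-60 cells (Homo sapiens) for cytotoxicity, read by luminescence and CellTiter-Glo, with a stated time of 3 days (a lower number here means a stronger inhibitor, a higher number a weaker inhibitor), compound 1 (`N#Cc1ccc(NC(=O)c2cc(-c3ccccc3)ccc2O)cc1`) gives 1350 nM as its half-maximal inhibitory concentration. Compound 3 (`O=C(Nc1ccc(OC(F)(F)F)cc1)c1cc(F)ccc1O`) gives 850 nM and stays within the usual scatter of compound 1, while compound 2 (`O=C(Nc1cc(C(F)(F)F)cc(C(F)(F)F)c1)c1ccc(Br)cc1O`) gives 270 nM and lies lower than compound 1, beyond that scatter. Compound 4 (`N#Cc1ccc(NC(=O)c2cc(Cl)ccc2O)cc1`) keeps the core of compound 1 but has chloro in place of phenyl on an aromatic carbon. Within the data shown here, no measured pair shows this change alone. Compound 2 (270 nM) and compound 3 (850 nM) also lack that phenyl but differ elsewhere too. In this assay a small move towards a lower number is therefore expected (a 1.7-fold lower number from compound 1 to compound 4 (0.23 log units; within the scatter)), one that stays within the scatter. Compound 4 is estimated at 800 nM (range 280 nM to 2300 nM).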

Compound 4, half-maximal inhibitory concentration: 700 nM
For compound 4 the middle estimate is 1.1-fold (0.06 log units) above the measured one, and the stated range covers the measured number.
By their numbers in this assay, from the lowest: compound 2; then compounds 4, 3 and 1 (each within the scatter of the next).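

In this assay, among these compounds, the one direct comparison at this position is a 1.9-fold lower number from compound 1 to compound 4 (0.29 log units; within the scatter) and it lies within the scatter, so the two numbers cannot be told apart. At this place, para to a hydroxy group, a single chloro can therefore stand in for a whole phenyl ring on this core without a step beyond the scatter. Nothing measured here explains this result.

As far as these compounds go, whether an amine or a carboxylic acid at this place would give a step beyond the scatter remains open. So does whether the phenyl-to-chloro swap gives a similar step on other cores.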